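A few compounds are considered here, and "the series" means these few. Any claim that something is new, unique, unknown or untested is made for them only; others in the source may bear on it.

Measured compounds:
compound 1 `O=C(/C(=C\c1cccc(Cl)c1Cl)SCc1ccc(Cl)cc1)c1ccc(Br)cc1` — 10000 nM
compound 2 `O=C(/C(=C\c1cccc(Cl)c1Cl)SCc1ccc(Cl)cc1)c1ccc(Cl)cc1` — 10000 nM

In a functional assay on DU-145 cells (Homo sapiens) for inhibition, read by trypan blue exclusion, with a stated time of 96 h (a higher number here means a weaker inhibitor of growth, a lower number a stronger inhibitor of growth), compound 1 gives 10000 nM, and compound 2 gives 10000 nM, so compound 1 stands level with compound 2. Within the data shown here, the one measured step, no change at the digits printed from compound 1 to compound 2 (within the scatter), changes only the ring attached to the carbonyl and shows no movement beyond the scatter.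

Compound 3 `CN(C)c1ccc(/C=C(/SCc2ccc(Cl)cc2)C(=O)c2ccc(Br)cc2)cc1` is reached from compound 1 by a different kind of change: 4-(dimethylamino)phenyl in place of 2,3-dichlorophenyl on a double-bonded chain carbon bound to a double-bonded chain carbon. Among the measured compounds shown here, no measured step touches this part of the shared core, so the halogen exchange from compound 1 to compound 2 does not bear on it, and the data give no direction for the step. Compound 1 gives 10000 nM, and that value is the only anchor. Compound 3 is therefore expected to lie near it, with wide uncertainty, at 6000 nM (range 1500 nM to 20000 nM). The expected step is a 1.7-fold lower number from compound 1 to compound 3 (0.22 log units; within the scatter).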

Compound 3, concentration for 50% growth inhibition: 10000 nM
For compound 3 the middle estimate is 1.7-fold (0.22 log units) below the measured one, within the range that was stated.
By their numbers in this assay, from the lowest: compounds 1, 2 and 3 (each within the scatter of the next).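

Where the earlier pair tested only the ring attached to the carbonyl, this result is the first reading at the other aryl position of the shared core. In this assay, putting 4-(dimethylamino)phenyl in place of 2,3-dichlorophenyl on a double-bonded chain carbon bound to a double-bonded chain carbon gives no change at the digits printed from compound 1 to compound 3 (within the scatter), so two quite different aromatic groups are indistinguishable here, with compound 3 at 10000 nM. Nothing available explains this outcome.

The compounds shown leave open whether a carboxylic acid, a primary amine or a longer chain in this same place would move the number beyond the scatter. They also do not show whether any other replacement on the shared core would give a stronger inhibitor of growth.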